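Amide variation on a shared core: two limits, one new analogue

A few compounds are considered here, and "the series" means these few. Any claim that something is new, unique, unknown or untested is made for them only; others in the source may bear on it.

Compound 1 `O=C(Nc1ccc(Cl)c(-c2nnc3c(Cl)cccn23)c1)c1cccnc1` in a functional assay on MDA-MB-231 cells (Homo sapiens) for antiproliferative activity, read by MTT assay, with stated times of 72 h and 4 h (a higher number here means a weaker inhibitor, a lower number a stronger inhibitor), gives > 100000 nM.
Compound 2 `CS(=O)(=O)c1ccc(C(=O)Nc2ccc(Cl)c(-c3nnc4c(Cl)cccn34)c2)cc1` in this assay gives > 100000 nM.

Both readings are limits of this assay, not numbers. The value of compound 1 is a limit. The value of compound 2 is likewise a limit. The step that the two limits leave unreadable from compound 1 to compound 2 therefore cannot be read in size or direction. On the numbers shown, compound 2 stands only at a limit, with no value inside the measured range of this assay, and the one other value shown is a limit too (the limit of > 100000 nM in this assay, at which 2 of the 2 values shown sit), so no measured step bears on the next change.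

Compound 3 `O=C(Nc1ccc(Cl)c(-c2nnc3c(Cl)cccn23)c1)c1ccon1` carries 1,2-oxazol-3-yl in place of 4-(methylsulfonyl)phenyl on a carbonyl carbon. With no readable step in the series, the only anchor is the position of compound 2 at the limit. Compound 3 is therefore expected to sit near that same limit, with an estimated step of a number no higher from compound 2 to compound 3 (the limit leaves the size open) that does not go beyond the scatter. The estimate for compound 3 in this assay is 100000 nM, with a range from 30000 nM to 300000 nM, most likely reported again as a limit.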

Compound 3, half-maximal inhibitory concentration: > 100000 nM
Compound 3: a limit, no number; the forecaster's own chance of this, stated with the estimate: 75%; the middle value lies on the limit itself.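

In this assay compound 3 gives > 100000 nM, which is a limit and not a number. No step can therefore be read among compound 1, compound 2 and compound 3: the limit of > 100000 nM in this assay, at which 3 of the 3 values shown sit.

The compounds shown leave open whether any group on this amide carbonyl carbon brings the shared core within the measured range of this assay.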